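The compounds below may be only part of what the source reports. "The series", "measured", "known", "first", "only" and "open" are said of these compounds alone.

Compound 1 `COc1ccc(SCc2ccc(/C=C/C(=O)Nc3ccccc3N)cc2)cc1OC` gives 14.3%
Compound 2 `Nc1ccccc1NC(=O)/C=C/c1ccc(CSc2cccc(F)c2)cc1` gives 8.56%
Compound 3 `Cc1ccc(SCc2ccc(C(=O)Nc3ccccc3N)cc2)cc1` gives 25.1%

In a functional assay on SMMC-7721 cells (Homo sapiens) for inhibition, read by CCK-8 assay, with a stated time of 72 h, tested at 2 uM (a higher number here means more inhibition of growth at the concentration tested, a lower number less inhibition of growth), compound 3 stands at the top with 25.1% as the highest of the three numbers, and its gaps to compound 1 and compound 2 both lie beyond the usual scatter.

Still unmeasured is compound 4 `Nc1ccccc1NC(=O)c1ccc(CSc2ccc(F)cc2)cc1` which keeps the core of compound 3 and alters a single group. The difference is fluoro in place of methyl on an aromatic carbon and in plain words this is fluoro in place of methyl on an aromatic carbon, so that 4-methylphenyl becomes 4-fluorophenyl.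

Within the data shown here, only one measured step touches the same part of the molecule. It is a number 5.7 percentage points lower from compound 1 to compound 2 (within the scatter) and it places 3-fluorophenyl where 3,4-dimethoxyphenyl sat on a sulfur. That step stays within the scatter, but it is a different swap on a different core, so it is only a weak guide. Among the measured compounds shown here, no measured pair compares methyl with fluoro directly.

The expected step is a number 5.1 percentage points lower from compound 3 to compound 4 (within the scatter) which means no change beyond the scatter is anticipated. Compound 4 is therefore estimated at 20% with an expected range from 8% to 33% as its likely span.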

Compound 4, percent growth inhibition at one concentration: 6.58%
Compound 4: middle estimate off by 13.4 percentage points, on the high side, outside the stated range (below it).
By their numbers in this assay, from the lowest: compounds 4, 2 and 1 (each within the scatter of the next); then compound 3.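

Fluoro in place of methyl on an aromatic carbon, para to a large group, gives a number 18.5 percentage points lower from compound 3 to compound 4 (beyond the scatter) in this assay and shows that this single position on the shared core can move the read-out beyond the scatter. The earlier compounds shown here offered only a swap of 3,4-dimethoxyphenyl for 3-fluorophenyl on a different core, which stayed within the scatter, whereas this pair compares methyl with fluoro directly, with one heavy atom exchanged and no change in the counted hydrogen-bond donors, acceptors or net charge. Nothing among the data given explains why the two groups differ in this way.

On these data alone, with only methyl and fluoro compared at this position, it remains open how other groups there, such as chloro, an amine or a longer chain, would behave and whether the position favours one kind of group over another. As far as these compounds go, it also remains open whether the same exchange would have a similar effect on the core of compound 1 , since this one pair cannot establish a pattern across cores.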